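Ethoxy to methyl: compound 3 to compound 4

This account rests on a few compounds, and the source may have more. Where it says the series, first, only, none or still open, it means among the compounds named here.

Compound 1 (`S=C(NCc1ccco1)Nc1ccccc1`) has the entry "not determined" (no result reported) in a toxicity assay on CHO cells (Cricetulus griseus) for cytotoxicity, read by MTT assay, with a stated time of 72 h (on this read-out higher numbers stand for weaker inhibition and lower numbers for stronger inhibition), and so offers no number. Compound 2 (`O=C1/C(=C/c2ccc(O)cc2)S/C(=N\c2ccccc2)N1Cc1ccco1`) stands at > 250000 nM in this assay as a limit and not a number. Compound 3 (`CCOc1ccc(/C=C2\S/C(=N\c3ccccc3)N(Cc3ccco3)C2=O)cc1`) also has no single number, its entry being "not determined" (no result reported) in this assay as well. Among the measured compounds shown here, the only reading near it is a limit (the limit of > 250000 nM in this assay, at which 1 of the 3 values shown sits). Compound 4 (`Cc1ccc(/C=C2\S/C(=N\c3ccccc3)N(Cc3ccco3)C2=O)cc1`) has not yet been measured. The change puts methyl in place of ethoxy on an aromatic carbon, para to a large group (methyl in place of ethoxy on an aromatic carbon). No measured step sizes such a change, so no shift beyond the usual scatter is expected in this assay in either direction. Compound 4 is estimated at 180000 nM with an expected range (from 60000 nM to 250000 nM).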

Compound 4, half-maximal inhibitory concentration: 185000 nM
Estimate against measurement, compound 4: 1.0-fold (0.01 log units) below; the measured number falls inside the stated range.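

Compound 4 gives 185000 nM in this assay, the first single number among the compounds shown. At this position, on an aromatic carbon para to a large group, methyl in place of hydroxy gives an at least 1.3-fold lower number from compound 2 to compound 4 (0.13 log units; that floor lies within the scatter), so the change is not shown to move the number beyond the scatter. Compound 2 stands at a limit and not a number: the limit of > 250000 nM in this assay, at which 1 of the 4 values shown sits.

The step from ethoxy to methyl cannot be read. As far as these compounds go, whether an amine or a carboxylic acid at this position would lower the number beyond the scatter remains open.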